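Naphthyl ester compound 4 expected close to compound 3

The source may hold more compounds than are shown below. What is called first, only, known or untested is meant among the compounds shown, and "the series" means these compounds.

For the measured compounds named here, compound 3 `CC(C)(C)c1ccc(OC(=O)c2cn(-c3ccccc3)nc2-c2ccncc2)cc1` is the only member of this group with a number: in a functional assay on HL-60 cells (Homo sapiens) for cytotoxicity, read by MTT assay, with a stated time of 48 h (a higher number here means a weaker inhibitor, a lower number a stronger inhibitor), compound 3 gives 18700 nM. Compound 1 `O=C(Oc1ccc2ccccc2c1)c1cn(-c2ccccc2)nc1-c1cccnc1` yielded no number, compound 1 being recorded in this assay as "nd(insoluble)" (no result reported). Compound 2 `CCc1ccc(OC(=O)c2cn(-c3ccccc3)nc2-c2ccncc2)cc1` likewise stands in this assay at "nd(insoluble)" (no result reported). Compound 4 `O=C(Oc1ccc2ccccc2c1)c1cn(-c2ccccc2)nc1-c1ccncc1` has not been measured; it differs from compound 3 by naphthalen-2-yl in place of 4-(tert-butyl)phenyl on an oxygen next to a carbonyl group. Going by the values given here, no measured pair shows this exchange, and the two entries without a number offer nothing on the size of a step. The step of a 1.1-fold higher number from compound 3 to compound 4 (0.03 log units; within the scatter) is expected to be none beyond the usual scatter, in either direction. Compound 4 is expected to give 20000 nM in this assay, within 6000 nM to 60000 nM, while a missing result remains a real possibility.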

Compound 4, half-maximal inhibitory concentration: > 100000 nM
Compound 4 gave a limit, no number (the forecaster's own chance of this, stated with the estimate: 40%); middle value at least 5.0-fold (0.69 log units) away from the limit.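

For the compounds shown here, at this position, on an oxygen next to a carbonyl group, the exchange of 4-(tert-butyl)phenyl for naphthalen-2-yl gives the first step that can be sized in this assay: an at least 5.3-fold higher number from compound 3 to compound 4 (0.72 log units; beyond the scatter). The two groups have the same count of heavy atoms, so that count alone does not set the outcome here. Compound 4 gives > 100000 nM, which is a limit and not a number.

Compound 1 and compound 2 give no number to compare. On these data alone, how a phenyl carrying an amine or a carboxylic acid would read in this place remains open.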